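Aryl amide variation in a thiourea-type series

The compounds below may be only part of what the source reports. "The series", "measured", "known", "first", "only" and "open" are said of these compounds alone.

Measured compounds:
- compound 1 `CC1=C(C(=O)Nc2ccc(C)cc2)C(c2cn(-c3ccccc3)nc2-c2ccccc2)NC(=S)N1`: in a functional assay on MCF7 cells (Homo sapiens) for inhibition, read by sulforhodamine B assay, with a stated time of 24 h (a higher number here means a weaker inhibitor of growth, a lower number a stronger inhibitor of growth), compound 1 gives 56100 nM
- compound 2 `COc1ccc(NC(=O)C2=C(C)NC(=S)NC2c2cn(-c3ccccc3)nc2-c2ccccc2)cc1`: in this assay compound 2 gives 77300 nM
- compound 3 `CC1=C(C(=O)Nc2ccccc2Cl)C(c2cn(-c3ccccc3)nc2-c2ccccc2)NC(=O)N1`: in this assay compound 3 gives 66600 nM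

Compound 2 holds the highest of the three numbers, yet its gaps to compound 3 and to compound 1 both lie within the scatter, so no order among the three can be read from them. For the measured compounds named here, the one measured step that changes only the aryl amide group, a 1.4-fold higher number from compound 1 to compound 2 (0.14 log units; within the scatter), is likewise within the scatter.

Compound 4 `CC1=C(C(=O)Nc2ccccc2Cl)C(c2cn(-c3ccccc3)nc2-c2ccccc2)NC(=S)N1` is not yet measured. Against compound 2 it shows (2-chlorophenyl in place of 4-methoxyphenyl on an amide-type nitrogen). Going by the values given here, the step from compound 1 to compound 2 is the only measured change at this position and it was flat. Compound 3 carries the same 2-chlorophenyl group on the amide nitrogen, differing from compound 4 only elsewhere, and its value sits close to that of compound 2. Among the compounds with values here, nothing among the measured compounds therefore points to a shift beyond the scatter in this assay for this change.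

Compound 4 is thus expected to give 65000 nM in this assay, within 30000 nM to 140000 nM, which means an expected step of a 1.2-fold lower number from compound 2 to compound 4 (0.08 log units; within the scatter).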

Compound 4, concentration for 50% growth inhibition: 68800 nM
Compound 4: middle estimate off by 1.1-fold (0.02 log units), on the low side; low and high end bracket the measured number.
By their numbers in this assay, from the lowest: compounds 1, 3, 4 and 2 (each within the scatter of the next).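

In this assay, bringing in 2-chlorophenyl on the amide-type nitrogen gives a 1.1-fold lower number from compound 2 to compound 4 (0.05 log units; within the scatter), and the comparison with the 4-methylphenyl amide gives a 1.2-fold higher number from compound 1 to compound 4 (0.09 log units; within the scatter); both steps are within the scatter. The earlier step covered only 4-methylphenyl and 4-methoxyphenyl, whereas this position now holds three aryl groups on the shared core, and the 2-chlorophenyl group, with its different substituent and substitution position, does not separate from the other two in this assay. No independent evidence is available to explain this flat reading.

From the compounds shown here alone, all three aryl amides on this core are substituted phenyl groups, so it remains open whether an amine, a carboxylic acid or a longer alkyl chain on the amide-type nitrogen would produce a step beyond the scatter. Also open is whether any change at this position could be resolved from a stronger starting point, since compound 1 gives 56100 nM and compound 2 gives 77300 nM, leaving the series without a markedly stronger reference compound among those shown.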